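A few compounds are considered here, and "the series" means these few. Any claim that something is new, unique, unknown or untested is made for them only; others in the source may bear on it.

Of the compounds shown here, three of one shared core have been measured in an assay on isolated protein for binding affinity to B1 bradykinin receptor (Homo sapiens) (a lower number here means a stronger inhibitor, a higher number a weaker inhibitor), and all of them come back only as limits. Compound 1 `Cc1cc(C)c2cccc(OCc3c(Cl)ccc(S(=O)(=O)NC4(C(=O)N5CCN(C(=O)[C@@H](N)CCCC[N+](C)(C)C)CC5)CCCC4)c3Cl)c2n1` gives < 10000 nM in this assay, which is a limit rather than a number. Compound 2 `Cc1cc(C)c2cccc(OCc3c(Cl)ccc(S(=O)(=O)NC4(C(=O)N5CCN(C(=O)CCCCC[N+](C)(C)C)CC5)CCCC4)c3Cl)c2n1` gives < 10000 nM in this assay, again a limit. Compound 3 `Cc1cc(C)c2cccc(OCc3c(Cl)ccc(S(=O)(=O)NC4(C(=O)N5CCN(C(=O)CCCC[N+](C)(C)C)CC5)CCCC4)c3Cl)c2n1` gives < 10000 nM in this assay, also a limit. Because of the limit of < 10000 nM in this assay, at which 3 of the 3 values shown sit, none of the steps among them can be sized: the step that the two limits leave unreadable from compound 1 to compound 2, the step that the two limits leave unreadable from compound 1 to compound 3 and the step that the two limits leave unreadable from compound 2 to compound 3 all stay hidden behind the same limit. So compound 2 stands at that limit and nowhere more exact.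

Compound 4 `Cc1cc(C)c2cccc(OCc3c(Cl)ccc(S(=O)(=O)NC4(C(=O)N5CCN(C(=O)[C@H](CCC[N+](C)(C)C)[N+](C)(C)C)CC5)CCCC4)c3Cl)c2n1` has not yet been measured. It differs from compound 2 by a group of 12 heavy atoms (10 carbon, 2 nitrogen; no ring) in place of a group of 9 heavy atoms (8 carbon, 1 nitrogen; no ring), on a carbonyl carbon. Going by the values given here, no measured step bears directly on this change, since the earlier steps, all unreadable, concern the amino group and the length of the chain, and none of them introduces a second charged nitrogen. All three measured compounds at least pass the limit, so compound 4 is expected to do the same, and the step that the limit leaves unreadable from compound 2 to compound 4 is offered only as a rough guess. Compound 4 is therefore estimated at 500 nM in this assay, within a wide range from 20 nM to 5000 nM.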

Compound 4, inhibition constant: < 10000 nM
Compound 4 ended at the assay's limit (the forecaster's own chance of this, stated with the estimate: 40%); the middle value is on the limit's open side.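

Compound 4 gives < 10000 nM in this assay, which is a limit and not a number. Its steps to compound 1, compound 2 and compound 3 therefore cannot be read, because all four compounds share one limit: the limit of < 10000 nM in this assay, at which 4 of the 4 values shown sit.

The compounds shown leave open what the actual value of each one is, and whether the second charged nitrogen in compound 4 changes it at all.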